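The source may report more compounds than this note shows. Statements on the series, on what has been measured and on what is new or still open speak of the compounds shown alone.

Compound 1 `Fc1ccc(N2CCN(c3nc(-n4ccc5ccccc54)c4ccccc4n3)CC2)cc1` gives 50 ug/mL
Compound 2 `CN1CCN(c2nc(-n3ccc4ccccc43)c3ccccc3n2)CC1` gives 6 ug/mL

For the measured compounds named here, in a functional assay on MCF7 cells (Homo sapiens) for antiproliferative activity, read by MTT assay (on this read-out higher numbers stand for weaker inhibition and lower numbers for stronger inhibition), compound 2 has the lower of the two numbers so far. Compound 3 `c1ccc(N2CCN(c3nc(-n4ccc5ccccc54)c4ccccc4n3)CC2)nc1` differs from it by pyridin-2-yl in place of methyl on an amine nitrogen in a ring in one change: pyridin-2-yl in place of methyl on an amine nitrogen in a ring. Going by the values given here, the only measured step at this place is an 8.3-fold lower number from compound 1 to compound 2 (0.92 log units; beyond the scatter) and it is modest, with methyl in place of 4-fluorophenyl. Read in reverse, that single step suggests a higher number for compound 3, by a similar or somewhat smaller amount. The expected change is a 5.0-fold higher number from compound 2 to compound 3 (0.70 log units; beyond the scatter) in this estimate. The estimated value for compound 3 is 30 ug/mL with 10 ug/mL to 80 ug/mL as the expected range.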

Compound 3, half-maximal inhibitory concentration: 50 ug/mL
Beside the measured number, compound 3's estimate is 1.7-fold (0.22 log units) below it; measured number inside the range.
By their numbers in this assay, from the lowest: compound 2; then compounds 1 and 3 (each within the scatter of the next).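

In this assay, pyridin-2-yl on the amine nitrogen in the ring gives the same picture as 4-fluorophenyl: methyl to pyridin-2-yl is an 8.3-fold higher number from compound 2 to compound 3 (0.92 log units; beyond the scatter), while pyridin-2-yl in place of 4-fluorophenyl is no change at the digits printed from compound 1 to compound 3 (within the scatter). The higher number is therefore not tied to the fluorine-bearing ring alone, and the two aromatic groups do not separate here. Nothing in hand explains this result. Open, going by these compounds, is whether ethyl, a longer chain or hydroxyethyl on that nitrogen stays with methyl. Also open, on these data alone, is where benzyl falls.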